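The source may hold more compounds than are shown below. What is called first, only, known or untested is meant among the compounds shown, and "the series" means these compounds.

Measured so far:

Compound 1, `OCCCCC(F)F`, in a physicochemical assay for lipophilicity, read by NMR (a lower number here means a more polar compound, a higher number a more lipophilic compound), gives 0.66.
Compound 2, `OCCC(F)CC(F)(F)F`, in this assay gives 0.84.
Compound 3, `OCCC(F)(F)CC(F)(F)F`, in this assay gives 1.12.

Compound 4, `OCCCCCF`, has not yet been measured. It differs from compound 1 in one place: hydrogen in place of fluoro on a saturated chain carbon bound to a fluorine atom and a saturated chain carbon. The same kind of change has already been made once among the measured compounds, where compound 2 differs from compound 3 by hydrogen in place of fluoro on a saturated chain carbon bound to a fluorine atom and two saturated chain carbons, and there it gave a number 0.28 log units lower from compound 3 to compound 2 (within the scatter). The two places are not identical, as the two descriptions of the place show, so the change is the same kind, not the same. The difference between the cores of compound 1 and compound 3 is not broken down here. Resting on that measured step, the step from compound 1 to compound 4 in this assay is expected to be a number 0.26 log units lower from compound 1 to compound 4 (within the scatter). Compound 4 is therefore estimated at 0.4, between 0.15 and 0.65.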

Compound 4, partition coefficient: 0.52
Compound 4: the middle estimate sits 0.12 log units below what was measured, and the stated range covers the measured number.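

In this assay, putting hydrogen in place of fluoro gives a number 0.14 log units lower from compound 1 to compound 4 (within the scatter) and, on the other core, a number 0.28 log units lower from compound 3 to compound 2 (within the scatter). Both steps lie within the scatter, so on these two cores the change shows no effect that can be told apart from repeat-measurement noise, and the two results agree only to that extent. For the compounds shown here, this does not show that the change has a fixed size from core to core, since the two places differ, only two examples exist, and no measurement here offers an explanation for either step.

The compounds shown leave open how the same change would behave on a longer chain. They also leave open what it would do in a core carrying an amine or a carboxylic acid.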